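Ester-chain change from compound 3 to compound 4

The compounds below may be only part of what the source reports. "The series", "measured", "known", "first", "only" and "open" are said of these compounds alone.

Measured so far in a functional assay on HEK293 cells for antagonist activity at Voltage-dependent L-type calcium channel subunit alpha-1D (Rattus norvegicus), read by FLIPR; on this read-out lower numbers stand for stronger inhibition and higher numbers for weaker inhibition:
compound 1 `CCOC(=O)C1=C(C)NC(CCl)=C(C(=O)OCC)C1c1cccc([N+](=O)[O-])c1`: 53 nM
compound 2 `CCOC(=O)C1=C(C)NC(/C=C/C#N)=C(C(=O)OCC)C1c1cccc([N+](=O)[O-])c1`: 45 nM
compound 3 `C#CCCOC(=O)C1=C(C)NC(C)=C(C(=O)OC)C1c1cccc([N+](=O)[O-])c1`: 35 nM

Compound 3 shows the lowest of the three numbers in this assay, yet its gaps to compound 2 and to compound 1 both lie within the scatter, so the three compounds are not separable on these data. For the measured compounds named here, the one step that alters a single place, a 1.2-fold lower number from compound 1 to compound 2 (0.07 log units; within the scatter), sits on a double-bonded ring carbon and is likewise within the scatter.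

Compound 4 `COC(=O)C1=C(C)NC(C)=C(C(=O)OCCC(C)c2ccccc2)C1c1cccc([N+](=O)[O-])c1` differs from compound 3 as follows: 1-phenylethyl in place of ethynyl on a saturated chain carbon, two bonds along the chain from an oxygen next to a carbonyl group. Going by the values given here, no measured pair touches the ester chain, so nothing bears directly on this change; the only guide is that every variant so far, whatever its substituent, lands in a narrow band. A step no larger than the scatter is therefore expected, with a 1.1-fold higher number from compound 3 to compound 4 (0.06 log units; within the scatter) as the estimated outcome. Compound 4 is expected to give about 40 nM in this assay, within 15 nM to 110 nM.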

Compound 4, half-maximal inhibitory concentration: 11 nM
Estimate against measurement, compound 4: 3.6-fold (0.56 log units) above; the whole stated range lies above it.
By their numbers in this assay, from the lowest: compound 4; then compounds 3, 2 and 1 (each within the scatter of the next).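

In this assay, for the compounds shown here, the ester chain gives the first single-place step beyond the scatter: 1-phenylethyl in place of ethynyl gives a 3.2-fold lower number from compound 3 to compound 4 (0.50 log units; beyond the scatter). This position therefore takes a much larger group, 8 heavy atoms with a six-membered aromatic ring against 2 heavy atoms in ethynyl, with a modest gain in inhibition rather than a loss. No measurement at hand accounts for this step.

Still open, from the compounds shown here alone, is whether the step rests on the aromatic ring, the chain length or the branching methyl, which a 3-phenylpropyl or a plain butyl ester would help to separate. Also open, going by these compounds, is whether a terminal amine or a longer chain is tolerated here, and whether the 3-phenylbutyl ester gives a similar step alongside the chloromethyl or 2-cyanoethenyl groups.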